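Pepsin Inhibitors: Methyl Removed from the Amide Chain

The source may report more compounds than this note shows. Statements on the series, on what has been measured and on what is new or still open speak of the compounds shown alone.

Measured so far:
compound 1, `CC(C)CC(=O)NC(C(=O)N[C@@H](CC(C)C)[C@@H](O)CC(C)C(=O)NC(C)C(=O)NC(=O)C(C)C)C(C)C`: 3 nM in an assay on isolated protein for inhibition of Pepsin A (Sus scrofa); a higher number here means a weaker inhibitor, a lower number a stronger inhibitor
compound 2, `CC(C)CCNC(=O)C(C)NC(=O)C(CC(=O)[C@H](CC(C)C)NC(=O)C(NC(=O)CC(C)C)C(C)C)Cc1ccccc1`: 72 nM in this assay

Compound 1 gives the lower of the two numbers. Among the measured compounds shown here, compound 2 stands at a number higher by a margin beyond the scatter, but the two structures differ in several places, so no single step between them can be read, and compound 2 serves only as a frame for the series.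

Compound 3, `CC(C)CC(=O)NC(C(=O)N[C@@H](CC(C)C)[C@@H](O)CC(C)C(=O)NCC(=O)NC(=O)C(C)C)C(C)C`, is not yet measured. It departs from compound 1 in one place: hydrogen in place of methyl on a saturated chain carbon bound to an amide-type nitrogen and a carbonyl carbon. The change is small, a methyl giving way to hydrogen on a saturated chain carbon bound to an amide-type nitrogen and a carbonyl carbon, with no ring, donor, acceptor or charge involved.

The expectation is a modest loss of potency, a step of a 3.3-fold higher number from compound 1 to compound 3 (0.52 log units; beyond the scatter) that would sit just beyond the scatter in the direction of a weaker inhibitor. Compound 3 is estimated at 10 nM in this assay, with a range from 3 nM to 40 nM.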

Compound 3, inhibition constant: 53 nM
Compound 3: the middle estimate sits 5.3-fold (0.72 log units) below what was measured, and the stated range ends below it.
By their numbers in this assay, from the lowest: compound 1; then compounds 3 and 2 (each within the scatter of the next).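

In this assay, the saturated chain carbon bound to an amide-type nitrogen and a carbonyl carbon proves sensitive to substitution: hydrogen in place of methyl gives an 18-fold higher number from compound 1 to compound 3 (1.25 log units; beyond the scatter), a large step for the loss of one carbon, with no ring, donor, acceptor or charge involved. Within this pair, the methyl is the better of the two groups at this position. No measurement at hand bears on why the step is this large, and its origin stays unassigned.

With only methyl and hydrogen shown at this carbon, it remains open whether an ethyl group, a longer chain, a hydroxymethyl group or an amine would match or improve on methyl. From the compounds shown here alone, whether the same replacement would cost as much on a different core also remains open.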